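Swapping the Amide Aryl Group on a Weak Antiproliferative Series

The source may hold more compounds than are shown below. What is called first, only, known or untested is meant among the compounds shown, and "the series" means these compounds.

Compound 1 `COc1ccccc1C(=O)Nc1cccc(-c2oc3cc(-c4ccc(F)cc4)ccc3c(=O)c2O)c1` was tested in a functional assay on HepG2 cells (Homo sapiens) for antiproliferative activity, read by CCK-8 assay, with a stated time of 72 h (a lower number here means a stronger inhibitor, a higher number a weaker inhibitor), and gave 14500 nM, the highest of the three numbers recorded so far. Compound 2 `COc1cccc(C(=O)Nc2cccc(-c3oc4cc(-c5ccc(F)cc5)ccc4c(=O)c3O)c2)c1` gives 9950 nM, and compound 3 `Cc1cc(C(=O)Nc2cccc(-c3oc4cc(-c5ccc(F)cc5)ccc4c(=O)c3O)c2)ccc1F` gives 9540 nM. Both were obtained from compound 1 by exchanging the ring that sits on the carbonyl carbon: a 1.5-fold lower number from compound 1 to compound 2 (0.16 log units; within the scatter) and a 1.5-fold lower number from compound 1 to compound 3 (0.18 log units; within the scatter), so neither exchange moved the number beyond the usual scatter of this measurement. Between the two new rings the gap was just as small: a 1.0-fold lower number from compound 2 to compound 3 (0.02 log units; within the scatter).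

Compound 4 `CCCc1ccc(C(=O)Nc2cccc(-c3oc4cc(-c5ccc(F)cc5)ccc4c(=O)c3O)c2)cc1` alters compound 1 in the same place: 4-propylphenyl in place of 2-methoxyphenyl on a carbonyl carbon. Because a 1.5-fold lower number from compound 1 to compound 2 (0.16 log units; within the scatter) and a 1.5-fold lower number from compound 1 to compound 3 (0.18 log units; within the scatter) both stayed within the scatter, no shift beyond the scatter is expected for compound 4 in this assay, at most a small drift toward a lower number. Compound 4 is therefore expected to give 10000 nM, within a range of 4000 nM to 25000 nM. The expected step is a 1.5-fold lower number from compound 1 to compound 4 (0.16 log units; within the scatter).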

Compound 4, half-maximal inhibitory concentration: 51500 nM
For compound 4 the middle estimate is 5.2-fold (0.71 log units) below the measured one; measured number above the stated range.
By their numbers in this assay, from the lowest: compounds 3, 2 and 1 (each within the scatter of the next); then compound 4.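

In this assay this place on the carbonyl carbon proves less tolerant than the first three compounds suggested, since the 4-propylphenyl group stands apart from all three earlier rings (a 3.6-fold higher number from compound 1 to compound 4 (0.55 log units; beyond the scatter); a 5.4-fold higher number from compound 3 to compound 4 (0.73 log units; beyond the scatter); a 5.2-fold higher number from compound 2 to compound 4 (0.71 log units; beyond the scatter)), and each step lies beyond the scatter. Losing the methoxy group cannot be the whole story, as compound 3 also lacks one yet sits within the scatter of compound 1 and compound 2. Nothing measured here explains the rise.

The compounds shown do not tell whether the propyl chain itself matters or whether any chain on this ring would give the same result. A shorter chain such as ethyl or methyl in place of propyl would test this, while an amine or a carboxylic acid on the ring would show how this place responds to a very different group.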